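The source may hold more compounds than are shown below. What is called first, only, known or untested is meant among the compounds shown, and "the series" means these compounds.

In a functional assay on MCF7 cells (Homo sapiens) for inhibition, read by colorimetric assay and MTT assay, with a stated time of 72 h (a lower number here means a stronger inhibitor, a higher number a weaker inhibitor), compound 1, with the structure `COc1ccc(C(=O)NNC(=S)Nc2csc(-c3ccccc3)c2)cc1OC`, gives 21000 nM. Compound 2, with the structure `COc1ccc(C(=O)NNC(=S)Nc2csc(-c3ccc(C)cc3)c2)cc1OC`, shares the core of compound 1 and differs from it in one place, (methyl in place of hydrogen on an aromatic carbon). In this assay compound 2 gives 11000 nM. That change brought a 1.9-fold lower number from compound 1 to compound 2 (0.28 log units; within the scatter).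

Compound 3, with the structure `Oc1ccc(-c2nnc(Nc3csc(-c4ccccc4)c3)s2)cc1`, is built on a different core; the difference between the two cores is not broken down here. In this assay compound 3 gives 24000 nM. This number and the number of compound 1 lie within the scatter of each other, so nothing can be said about which of the two is the stronger inhibitor; the number of compound 3 and the number of compound 2, however, lie beyond the scatter.

Compound 4, with the structure `Cc1ccc(-c2cc(Nc3nnc(-c4ccc(O)cc4)s3)cs2)cc1`, has not yet been measured. It differs from compound 3 by methyl in place of hydrogen on an aromatic carbon. This is the same change that led from compound 1 to compound 2, made on the core of compound 3 instead. The expected step for compound 4 in this assay is a 1.7-fold lower number from compound 3 to compound 4 (0.23 log units; within the scatter), which rests on the earlier step of a 1.9-fold lower number from compound 1 to compound 2 (0.28 log units; within the scatter) and on the assumption that it carries over to the core of compound 3, for which nothing else is yet known. On that basis compound 4 is estimated to give about 14000 nM in this assay, with a likely range from 6000 nM to 35000 nM.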

Compound 4, half-maximal inhibitory concentration: 8000 nM
Estimate against measurement, compound 4: 1.8-fold (0.24 log units) above, within the range that was stated.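

On the core of compound 3, replacing phenyl with 4-methylphenyl brought, in this assay, a 3.0-fold lower number from compound 3 to compound 4 (0.48 log units; beyond the scatter). This step is beyond the scatter, while the earlier step on the other core is within it, yet the two steps cannot be told apart in size, so the change carried over from one core to the other as far as these numbers can show: the same change on two cores in this assay, a 1.9-fold lower number (0.28 log units; within the scatter) from compound 1 to compound 2 and a 3.0-fold lower number (0.48 log units; beyond the scatter) from compound 3 to compound 4, 1.6-fold (0.20 log units) apart, within the scatter of two such steps. For the compounds shown here, this is only one pair of steps on two cores in a single assay, so it does not prove that the two steps are equal in size, does not show that the change would carry over to a third core, and gives no explanation of why the number falls.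

What the compounds shown leave open is whether a longer chain such as ethyl, a chlorine atom or an amine in the same place on the ring would lower the number further, leave it unchanged or raise it. As far as these compounds go, it also remains open whether the step from phenyl to 4-methylphenyl would hold on either core in another cell line or in a test on an isolated protein.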